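A few compounds are considered here, and "the series" means these few. Any claim that something is new, unique, unknown or untested is made for them only; others in the source may bear on it.

Measured compounds and their values:
- Compound 1 `Cn1cnc2c(Nc3ccccc3)ncnc21`: 0%
- Compound 2 `Cn1cnc2c(Nc3ccc(F)cc3)ncnc21`: 8%
- Compound 3 `c1ccc(Sc2ncnc3[nH]cnc23)cc1`: 0%

All three were tested in an assay on isolated protein for inhibition of Ca2+/calmodulin-dependent protein kinase II (CaM kinase II) (Rattus norvegicus), tested at 30 uM; a lower number here means less inhibition, a higher number more inhibition at the concentration tested (going by the name of the read-out). In this assay, among the compounds with values here, compound 1 gives 0% and compound 2 gives 8%; the single change between them is fluoro in place of hydrogen on an aromatic carbon, and the step it made is a number 8 percentage points higher from compound 1 to compound 2 (within the scatter). Compound 3 carries a different core; how it differs from the core of compound 1 is not broken down here. In this assay compound 3 gives 0%, level with compound 1 and, together with it, the lowest of the three numbers.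

Compound 4 `Fc1ccc(Sc2ncnc3[nH]cnc23)cc1` has not yet been measured. It is made from compound 3 by fluoro in place of hydrogen on an aromatic carbon, the same kind of change that turns compound 1 into compound 2, placed in the same way on the six-membered ring. Since that earlier change moved the read-out only by a number 8 percentage points higher from compound 1 to compound 2 (within the scatter), a small step is expected here as well, estimated as a number 4 percentage points higher from compound 3 to compound 4 (within the scatter). The read-out for compound 4 is therefore expected to be about 4%, likely between 0% and 15%.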

Compound 4, a percentage reported as inhibition, at one concentration (the size of the read-out at that concentration, not a potency): 0%
Beside the measured number, compound 4's estimate is 4 percentage points above it; low and high end bracket the measured number.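

In this assay, placing fluoro in place of hydrogen on the six-membered aromatic ring of carbon only, para to a large group, gives no change at the digits printed from compound 3 to compound 4 (within the scatter). Set beside the same change on the core of compound 1, the result on the second core gives no sign that the two cores respond differently: the same change on two cores in this assay, a number 8 percentage points higher (within the scatter) from compound 1 to compound 2 and no change at the digits printed (within the scatter) from compound 3 to compound 4, 8 percentage points apart, within the scatter of two such steps. Within the data shown here, this shows that the change stayed small on both cores, but it does not show that its effect is truly the same on each, as every number here lies close to no inhibition at all and only two cores can be compared, so a modest difference between them could stay hidden.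

Going by these compounds, what remains open is whether any replacement at this place on the ring can raise inhibition clearly above the scatter, for example an amine, a carboxylic acid or a longer chain in place of the fluoro. On these data alone, it is also open whether such a group would behave alike on both cores, which only values well clear of no inhibition could show.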